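Series notes: N-aryl variation on a shared amide core

This account rests on a few compounds, and the source may have more. Where it says the series, first, only, none or still open, it means among the compounds named here.

The set holds two aryl variants of one core. Compound 1, `Cn1ccc2c(Oc3ccc(NC(=O)c4cc5cccnc5n(-c5ccc(Cl)cc5)c4=O)cc3)ccnc21`, carries a 4-chlorophenyl group on the aromatic nitrogen; in a functional assay on NCI-H460 cells (Homo sapiens) for antiproliferative activity, read by MTT assay, with a stated time of 72 h (on this read-out lower numbers stand for stronger inhibition and higher numbers for weaker inhibition), compound 1 is recorded as "not determined" (no result reported), so nothing can be said of where it stands. Among the compounds with values here, compound 2, `Cn1ccc2c(Oc3ccc(NC(=O)c4cc5cccnc5n(-c5ccc(F)c(Cl)c5)c4=O)cc3)ccnc21`, is the only member with a value: in this assay compound 2 gives 1210 nM, which makes it the sole reference point of the series rather than a ranked member.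

Compound 3, `Cn1ccc2c(Oc3ccc(NC(=O)c4cc5cccnc5n(-c5ccc(C(F)(F)F)cc5Cl)c4=O)cc3)ccnc21`, is not yet measured. The change from compound 2 to compound 3 is 2-chloro-4-(trifluoromethyl)phenyl in place of 3-chloro-4-fluorophenyl on an aromatic nitrogen. Within the data shown here, no step between measured compounds exists to calibrate how the aryl pattern shifts activity, so the direction of the move is open. The expectation is a step from compound 2 to compound 3 of a 1.3-fold higher number from compound 2 to compound 3 (0.12 log units; within the scatter), no larger than the usual scatter, with the wider uncertainty leaning toward weaker inhibition. Compound 3 is therefore estimated at 1600 nM in this assay, with a range from 500 nM to 5500 nM.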

Compound 3, half-maximal inhibitory concentration: 6950 nM
The estimate for compound 3 lay 4.3-fold (0.64 log units) below the measured number, outside the stated range (above it).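

Working notes: in this assay the aryl group on the aromatic nitrogen is not a silent position, since 2-chloro-4-(trifluoromethyl)phenyl in place of 3-chloro-4-fluorophenyl gives a 5.7-fold higher number from compound 2 to compound 3 (0.76 log units; beyond the scatter) and the shift toward weaker inhibition lies beyond the usual scatter. Within the data shown here, this is the first readable step, and it shows that the aryl substitution pattern can move this read-out even though the shared core stays unchanged. The change alters the chlorine placement and exchanges fluorine for trifluoromethyl in a single move, so the step cannot be divided between those two parts, and nothing available bears on the origin of the shift.

Compound 1 carries no number, so the steps that would place its 4-chlorophenyl group against the other two aryl patterns cannot be read. On these data alone, it remains open whether a phenyl ring with a single chlorine or a single trifluoromethyl would separate the two parts of the change, and how a ring bearing an aminomethyl group or a carboxylic acid would behave at this position.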